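This account rests on a few compounds, and the source may have more. Where it says the series, first, only, none or still open, it means among the compounds named here.

Measured so far:
Compound 1 `CCCn1c(-c2ccccc2)nc2c(NC3CCC3)ncnc21` gives 15 nM
Compound 2 `Cn1c(-c2ccc(O)cc2)nc2c(NC3CCCC3)ncnc21` gives 17 nM
Compound 3 `CCn1c(-c2ccccc2)nc2c(N)ncnc21` gives 31 nM

All three numbers come from an assay on CHO cells for displacement of a labelled ligand from adenosine receptor A1 (Homo sapiens), read by scintillation counting, with a stated time of 3 h; a lower number here means a stronger inhibitor, a higher number a weaker inhibitor. Compound 2 stands second highest of the three. Its nearest neighbour is compound 1, whose number is only slightly lower; its furthest is compound 3, whose number is somewhat higher. Both gaps lie within the usual scatter of repeated measurements, so the three compounds cannot be told apart on these numbers, and none can be called the strongest or the weakest.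

The next compound, compound 4 `Cn1c(-c2ccccc2)nc2c(NC3CCCC3)ncnc21`, has not yet been measured in this assay. It differs from compound 2 in one place only: hydrogen in place of hydroxy on an aromatic carbon. The hydroxy sits on the aromatic carbon of the six-membered ring of carbon only, para to a large group, and it is replaced by a hydrogen atom.

Within the data shown here, no measured pair of compounds shows this exact change on its own, so the expected size of the step rests on the overall picture. Compound 1 and compound 3, which both carry a plain phenyl, sit close to compound 2 in this assay, so the change is expected to move the number little if at all, and the step is estimated as a 1.2-fold higher number from compound 2 to compound 4 (0.07 log units; within the scatter), within the scatter. Compound 4 is therefore expected to give about 20 nM in this assay, most likely between 7 nM and 60 nM.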

Compound 4, inhibition constant: 2.8 nM
Compound 4: middle estimate off by 7.1-fold (0.85 log units), on the high side; measured number outside the range, below it.
By their numbers in this assay, from the lowest: compound 4; then compounds 1, 2 and 3 (each within the scatter of the next, the first and the last beyond it).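

Going from the 4-hydroxyphenyl to the phenyl gives a 6.1-fold lower number from compound 2 to compound 4 (0.78 log units; beyond the scatter) in this assay, and this is the first step in the set that isolates a single change. The earlier compounds shown here differ from one another in more than one place and could not be told apart, so they gave no direct reading of this position; this pair shows that what sits on the aromatic carbon para to a large group matters, with the hydrogen giving the stronger inhibitor and the hydroxy the weaker one. Nothing measured here explains why the number moves in this direction.

Going by these compounds, with only hydrogen and hydroxy compared at this position, it remains open where a methoxy group, a fluorine atom, an amine or a carboxylic acid would fall on the same scale. On these data alone, it is also open whether the same change would give a step of similar size on a compound that differs elsewhere, for example one with the longer chain of compound 1.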